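A few compounds are considered here, and "the series" means these few. Any claim that something is new, unique, unknown or untested is made for them only; others in the source may bear on it.

Compound 1 `O=c1ccoc2cc(OCc3cn(Cc4ccc(F)cc4)nn3)ccc12` and compound 2 `N#Cc1ccc(Cn2cc(COc3ccc4c(=O)ccoc4c3)nn2)cc1` share one core and differ only in the group carried on the saturated chain carbon bound to an aromatic nitrogen. In a functional assay on HeLa cells (Homo sapiens) for cytotoxicity, read by MTT assay, with a stated time of 48 h (a lower number here means a stronger inhibitor, a higher number a weaker inhibitor), compound 1 gives 12000 nM. For compound 2 this assay reports only a limit, > 100000 nM. Compound 2 therefore stands at the limit of > 100000 nM in this assay, at which 1 of the 2 values shown sits, and the step of an at least 8.3-fold higher number from compound 1 to compound 2 (0.92 log units; beyond the scatter) is known only as a bound. Compound 3 `O=c1ccoc2cc(OCc3cn(Cc4ccccc4Br)nn3)ccc12` differs from compound 2 by 2-bromophenyl in place of 4-cyanophenyl on a saturated chain carbon bound to an aromatic nitrogen. For the measured compounds named here, the single measured step that bears on this change is an at least 8.3-fold higher number from compound 1 to compound 2 (0.92 log units; beyond the scatter), in which fluoro rather than cyano went with the lower number; with bromine entering in place of the nitrile, compound 3 is expected to move back toward the number seen for compound 1. For compound 3 the estimate is 20000 nM, with a range from 5000 nM to 100000 nM, which means an expected step of an at least 5.0-fold lower number from compound 2 to compound 3 (0.69 log units; beyond the scatter).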

Compound 3, half-maximal inhibitory concentration: 14500 nM
Estimate against measurement, compound 3: 1.4-fold (0.14 log units) above; the measured number falls inside the stated range.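

Changing 4-cyanophenyl to 2-bromophenyl on the saturated chain carbon bound to an aromatic nitrogen gives an at least 6.8-fold lower number from compound 2 to compound 3 (0.83 log units; beyond the scatter) in this assay, so a measured number returns with this change. Compound 2 counts here only as a limit of the assay, which makes that step a bound: the limit of > 100000 nM in this assay, at which 1 of the 3 values shown sits. With a 1.2-fold higher number from compound 1 to compound 3 (0.08 log units; within the scatter), 2-bromophenyl and 4-fluorophenyl cannot be told apart at this position, and among the three compounds only compound 2, with its nitrile, stands apart.

Compound 1 and compound 3 differ in both the halogen and its place on the phenyl ring, and these two changes remain unseparated. As far as these compounds go, whether 4-bromophenyl would match them, and whether a phenyl ring carrying an amine or a carboxylic acid would behave like 4-cyanophenyl, stays open.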